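Replacing the isoindoline arm of compound 1

This account rests on a few compounds, and the source may have more. Where it says the series, first, only, none or still open, it means among the compounds named here.

Going by the values given here, compound 1 `O=C(O)CCCSCCN1C(=O)CC[C@@H]1/C=C/[C@@H](O)Cc1cccc(N2Cc3ccccc3C2)c1` gives 4.4 nM in an assay on CHO cells for displacement of a labelled ligand from prostaglandin E2 receptor EP4 subtype (Mus musculus), read by scintillation counting, with a stated time of 60 min (on this read-out higher numbers stand for weaker inhibition and lower numbers for stronger inhibition), the highest of the two numbers so far. Compound 2 `O=C(O)CCCSCCN1C(=O)CC[C@@H]1/C=C/[C@@H](O)Cc1cccc(-c2cc3ccccc3o2)c1` gives 0.1 nM, and the step of a 44-fold lower number from compound 1 to compound 2 (1.64 log units; beyond the scatter) shows that exchanging this arm can move the number a great deal. Compound 3 `O=C(O)CCCSCCN1C(=O)CC[C@@H]1/C=C/[C@@H](O)Cc1cccc(OCc2ccncc2)c1` differs from compound 1 by a group of 8 heavy atoms (6 carbon, 1 nitrogen, 1 oxygen; one six-membered aromatic ring with 1 hetero atom) in place of a group of 9 heavy atoms (8 carbon, 1 nitrogen; one five-membered non-aromatic ring with 1 hetero atom, one six-membered aromatic ring of carbon only), on an aromatic carbon. Among the compounds with values here, the only measured step replaces the same arm with a different group, so it sets no direction for this change. A broad estimate is therefore expected: a 1.1-fold higher number from compound 1 to compound 3 (0.06 log units; within the scatter), giving compound 3 an estimated 5 nM with a range of 0.8 nM to 30 nM.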

Compound 3, inhibition constant: 28 nM
Estimate against measurement, compound 3: 5.6-fold (0.75 log units) below; low and high end bracket the measured number.
By their numbers in this assay, from the lowest: compound 2; then compound 1; then compound 3.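

The (pyridin-4-yl)methoxy arm shows that exchange at this aromatic carbon can also raise the number, with a 6.4-fold higher number from compound 1 to compound 3 (0.80 log units; beyond the scatter) set against the earlier fall from the isoindoline arm. The range at this place is much wider than the first pair showed, with a 280-fold higher number from compound 2 to compound 3 (2.45 log units; beyond the scatter) separating the 1-benzofuran-2-yl and (pyridin-4-yl)methoxy arms.

A benzyloxy arm, with a carbon-only ring on the same oxygen link, would separate the contribution of the pyridine nitrogen from that of the link. No other measurement bears on why these steps arise.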